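The compounds below may be only part of what the source reports. "The series", "measured", "known", "first", "only" and "open" are said of these compounds alone.

Working notes on the series. In a functional assay on PBMC cells (Homo sapiens) for inhibition (on this read-out higher numbers stand for weaker inhibition and lower numbers for stronger inhibition), compound 1 `NC(=O)CC[C@H](N)C(=O)NS(=O)(=O)OC[C@H]1O[C@@H](n2cnc3c(N)ncnc32)[C@H](O)[C@@H]1O` gives 800 nM and compound 2 `CSCC[C@H](N)C(=O)NS(=O)(=O)OC[C@H]1OC[C@@H](n2cnc3c(N)ncnc32)[C@H](O)[C@@H]1O` gives 5200 nM. Compound 2 thus stands at the highest of the two numbers, and its nearest neighbour is compound 1 with a clearly lower number, the gap between the two lying beyond the scatter of this assay. Among the compounds with values here, no single-point step between measured compounds is available within the set.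

Compound 3 `Nc1ncnc2c1ncn2[C@@H]1CO[C@H](COS(=O)(=O)NC(=O)[C@@H]2CCCN2)[C@@H](O)[C@H]1O` keeps the core of compound 2 and differs from it only at the acyl part on the carbonyl carbon whose other neighbour is the amide-type nitrogen: pyrrolidin-2-yl in place of 1-amino-3-(methylsulfanyl)propyl on a carbonyl carbon

Within the data shown here, with no measured step of this kind to lean on, the size of the change in this assay from compound 2 to compound 3 is expected to be modest and its direction uncertain, leaning slightly towards a higher number a 1.3-fold higher number from compound 2 to compound 3 (0.13 log units; within the scatter). For compound 3 the value in this assay is estimated at 7000 nM, with a range from 1500 nM to 30000 nM.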

Compound 3, half-maximal inhibitory concentration: 750 nM
For compound 3 the middle estimate is 9.3-fold (0.97 log units) above the measured one; measured number outside the range, below it.
By their numbers in this assay, from the lowest: compounds 3 and 1 (each within the scatter of the next); then compound 2.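

In this assay, within the data shown here, the acyl part on the carbonyl carbon matters on this core: a 6.9-fold lower number from compound 2 to compound 3 (0.84 log units; beyond the scatter), the first single-place step. The lower number comes with pyrrolidin-2-yl, so on this core neither the open chain nor the sulfur of 1-amino-3-(methylsulfanyl)propyl is required for a number at the level of compound 3. Nothing at hand accounts for the size of this step.

Among these compounds, the single step swaps the open chain for a ring and removes the sulfur together, leaving open which of these changes goes with the lower number; 1-aminopentyl, an open chain without sulfur, or piperidin-2-yl, a larger ring, on the same carbonyl carbon would help separate them. From the compounds shown here alone, whether pyrrolidin-2-yl has the same effect on the core of compound 1 also remains open.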